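This account rests on a few compounds, and the source may have more. Where it says the series, first, only, none or still open, it means among the compounds named here.

Measured compounds in an ADME assay on KB cells (Homo sapiens) for cytotoxicity; on this read-out lower numbers stand for an effect already at smaller amounts and higher numbers for an effect only at larger amounts of compound:
compound 1 `CCOC(=O)N1[C@@H]2C=C[C@@](OC)(C(=O)c3c2cc(OC)c(OC)c3OCc2ccc(F)cc2)N1C(=O)OCC` gives 51.8 ug/mL
compound 2 `COC(=O)N1[C@@H]2C=C[C@@](OC)(C(=O)c3c2cc(OC)c(OC)c3OCc2ccccc2F)N1C(=O)OC` gives 137 ug/mL
compound 3 `CCCOc1c(OC)c(OC)cc2c1C(=O)[C@]1(OC)C=C[C@H]2N(C(=O)OCC(C)C)N1C(=O)OCC(C)C` gives 299 ug/mL

Compound 1 stands lowest of the three numbers in this assay. Its nearest neighbour is compound 2, whose number is higher by a margin beyond the usual scatter; compound 3 lies furthest, higher still and also beyond the scatter. Compound 2 and compound 3 each differ from compound 1 in more than one place, so no single change can be read off from those pairs.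

Compound 4 `CCOC(=O)N1[C@@H]2C=C[C@@](OC)(C(=O)c3c2cc(OC)c(OC)c3OCc2ccccc2F)N1C(=O)OCC` has not yet been measured in this assay. It shares all atoms with compound 1, joined differently: 2-fluorophenyl in place of 4-fluorophenyl on a saturated chain carbon bound to an oxygen on an aromatic ring. Within the data shown here, no single-change step between measured compounds is available to calibrate this move. What the set does show is that compound 2, which carries the 2-fluorophenyl group together with other changes, gives 137 ug/mL, a number above compound 1 but not far above it. For compound 4 a small step in this assay is therefore expected, more likely toward a higher number than a lower one, and possibly within the scatter. The expected value for compound 4 is 70 ug/mL, with a range from 30 ug/mL to 160 ug/mL. This amounts to an expected step of a 1.4-fold higher number from compound 1 to compound 4 (0.13 log units; within the scatter).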

Compound 4, concentration for half-maximal effect: 99.7 ug/mL
Compound 4: the middle estimate sits 1.4-fold (0.15 log units) below what was measured, within the range that was stated.
By their numbers in this assay, from the lowest: compounds 1, 4 and 2 (each within the scatter of the next, the first and the last beyond it); then compound 3.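

In this assay, 2-fluorophenyl in place of 4-fluorophenyl on a saturated chain carbon bound to an oxygen on an aromatic ring gives a 1.9-fold higher number from compound 1 to compound 4 (0.28 log units; within the scatter), the only single-change step among the compounds shown. At this position, therefore, exchanging these two fluorophenyl groups, which leaves the atoms the same and joins them differently, produces no difference that can be separated from the scatter of this read-out, though this rests on one pair and supports no wider pattern. No supporting measurement bears on the reason for this outcome.

From the compounds shown here alone, whether the same position responds to a larger change remains open, for instance an amine or a carboxylic acid in place of the fluorine, or a longer chain in place of the fluorophenyl group. The contribution of the carbamate groups and of the chain on the oxygen also stays unresolved in this assay, since the compounds shown offer no single-change step for either.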